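A fluorinated ring exchanged on compound 2

The source may hold more compounds than are shown below. What is called first, only, known or untested is meant among the compounds shown, and "the series" means these compounds.

Measured in a functional assay on HepG2 cells (Homo sapiens) for antiproliferative activity, read by sulforhodamine B assay, with a stated time of 48 h (a higher number here means a weaker inhibitor, a lower number a stronger inhibitor), so far
Compound 1 `COc1ccc(C(=O)/C=C/c2ccccc2-c2ccc(F)nc2)cc1` gives 8200 nM in this test
Compound 2 `O=C(/C=C/c1ccccc1-c1ccc(F)cc1)c1cccc(O)c1` gives 4200 nM in this test

These two values lie within the usual scatter of each other, so compound 2 cannot be ranked against compound 1. Compound 3 `O=C(/C=C/c1ccccc1-c1ccc(F)nc1)c1cccc(O)c1` awaits measurement and has 6-fluoropyridin-3-yl in place of 4-fluorophenyl on an aromatic carbon of compound 2 (6-fluoropyridin-3-yl in place of 4-fluorophenyl on an aromatic carbon). Within the data shown here, no measured pair shows this change alone. Compound 1, which also carries 6-fluoropyridin-3-yl, gives 8200 nM and so offers no sign of a shift, and no step beyond the scatter is expected in this assay here. The estimated step of a 1.2-fold higher number from compound 2 to compound 3 (0.08 log units; within the scatter) is therefore small. For compound 3 the estimated value is 5000 nM with a likely range from 1800 nM to 14000 nM in this measurement.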

Compound 3, half-maximal inhibitory concentration: 6400 nM
For compound 3 the middle estimate is 1.3-fold (0.11 log units) below the measured one; the measured number falls inside the stated range.
By their numbers in this assay, from the lowest: compounds 2, 3 and 1 (each within the scatter of the next).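

In this assay, 6-fluoropyridin-3-yl in place of 4-fluorophenyl brings a 1.5-fold higher number from compound 2 to compound 3 (0.18 log units; within the scatter) and so, on this aromatic carbon ortho to a large group, the ring nitrogen makes no readable difference. On the carbonyl carbon, 3-hydroxyphenyl in place of 4-methoxyphenyl brings a 1.3-fold lower number from compound 1 to compound 3 (0.11 log units; within the scatter) and is equally unreadable on this ring background. Nothing available bears on why these numbers lie so close. Open, as far as these compounds go, is whether an amine or a carboxylic acid in place of the fluorine would move the number beyond the scatter.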